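From compound 3 to compound 4: a bromine enters

The compounds below may be only part of what the source reports. "The series", "measured", "known", "first", "only" and "open" are said of these compounds alone.

Three esters of the same chromone core have been measured in a functional assay on cells (T-cell, Mus musculus, strain BALB/c) for inhibition, read by MTT assay, with a stated time of 72 h; on this read-out higher numbers stand for weaker inhibition and lower numbers for stronger inhibition. Compound 1 `COC(=O)c1c(F)cccc1OC(=O)COc1cc(O)c2c(=O)cc(-c3ccccc3)oc2c1` gives 40300 nM; compound 2 `COC(=O)c1cccc(Cl)c1OC(=O)COc1cc(O)c2c(=O)cc(-c3ccccc3)oc2c1` gives 38700 nM; compound 3 `COC(=O)c1cccc(C)c1OC(=O)COc1cc(O)c2c(=O)cc(-c3ccccc3)oc2c1` gives 39100 nM. Compound 3 therefore sits within the scatter of both neighbours: the step of a 1.0-fold lower number from compound 1 to compound 3 (0.01 log units; within the scatter) and the step of a 1.0-fold higher number from compound 2 to compound 3 (0.00 log units; within the scatter) are each too small to count, as is a 1.0-fold lower number from compound 1 to compound 2 (0.02 log units; within the scatter) between the other two.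

Compound 4 `COC(=O)c1c(Br)cccc1OC(=O)COc1cc(O)c2c(=O)cc(-c3ccccc3)oc2c1` has not yet been measured. It differs from compound 3 in one place: a group of 11 heavy atoms (8 carbon, 2 oxygen, 1 bromine; one six-membered aromatic ring of carbon only) in place of a group of 11 heavy atoms (9 carbon, 2 oxygen; one six-membered aromatic ring of carbon only), on an oxygen next to a carbonyl group. The measured steps that bear on this are the exchanges of a substituent on that same aromatic ring, fluorine, chlorine and methyl, and none of them moved the number beyond the scatter in this assay. Bromine is one more such exchange on the same ring, so no step beyond the scatter is expected for compound 4 in this assay, and the step of a 1.0-fold lower number from compound 3 to compound 4 (0.00 log units; within the scatter) is estimated to be flat. Compound 4 is expected to give about 39000 nM, with a range from 20000 nM to 78000 nM.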

Compound 4, half-maximal inhibitory concentration: 41700 nM
For compound 4 the middle estimate is 1.1-fold (0.03 log units) below the measured one; the measured number falls inside the stated range.
By their numbers in this assay, from the lowest: compounds 2, 3, 1 and 4 (each within the scatter of the next).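

In this assay, for the compounds shown here, the exchange of fluoro for bromo on an aromatic carbon comes to a 1.0-fold higher number from compound 1 to compound 4 (0.01 log units; within the scatter), the first direct comparison of these two halogens. The exchanges of the whole group on an oxygen next to a carbonyl group come to a 1.1-fold higher number from compound 3 to compound 4 (0.03 log units; within the scatter) and a 1.1-fold higher number from compound 2 to compound 4 (0.03 log units; within the scatter), so the flat behaviour seen among the fluoro, chloro and methyl compounds now extends to a bromo compound, and this read-out does not separate any of the four. Nothing at hand accounts for this insensitivity to the change.

On these data alone, all four compounds carry a substituent of the same small kind on that aromatic ring, so it remains open whether an amine or a carboxylic acid there would move the number beyond the scatter. They also share the methyl ester and the core, which leaves open whether a longer chain in place of the methyl, or a change elsewhere in the molecule, would shift the number.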